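This account rests on a few compounds, and the source may have more. Where it says the series, first, only, none or still open, it means among the compounds named here.

Measured so far in a functional assay on the whole organism (strain CD-1) with Mus musculus as the target, with a stated time of 0.5 h; a higher number here means that more compound is needed for the effect, a lower number that less compound is needed:
- compound 1, `CC1(c2ccccc2)CC(=O)N(CC(=O)N2CCN(c3ccc(F)cc3)CC2)C1=O`: "not active" (no number reported)
- compound 2, `CC1(c2ccccc2)CC(=O)N(CC(=O)N2CCN(c3cccc(Cl)c3)CC2)C1=O`: "not active" (no number reported)
- compound 3, `COc1cccc(N2CCN(C(=O)CN3C(=O)CC(C)(c4ccccc4)C3=O)CC2)c1`: 100 mg/kg

Compound 2 stands without a number in this assay; its entry, like that of compound 1, reports no dose. Only compound 3 has a figure in this assay. Compound 4, `CC1(c2ccccc2)CC(=O)N(CC(=O)N2CCN(c3cccc(Cl)c3Cl)CC2)C1=O`, is not yet measured. The change from compound 2 to compound 4 is chloro in place of hydrogen on an aromatic carbon. For the measured compounds named here, no step between measured compounds is available, so no direction for this change can be read from the series; the expectation is for no change beyond the usual scatter, with a real chance that compound 4 again returns no number in this assay. Compound 4 is estimated at 100 mg/kg in this assay, in the range 30 mg/kg to 300 mg/kg.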

Compound 4, minimum effective dose: 300 mg/kg
The estimate for compound 4 lay 3.0-fold (0.48 log units) below the measured number, and the stated range covers the measured number.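

With 2,3-dichlorophenyl on the ring amine nitrogen, this assay now holds a second number for this position, and the exchange for 3-methoxyphenyl reads as a 3.0-fold higher number from compound 3 to compound 4 (0.48 log units; beyond the scatter). The added chloro, ortho to a chloro group, goes with a reported dose for compound 4, whereas compound 2 gives "not active" (no number reported), so that step cannot be read as a size. Nothing available explains either difference.

Still open, on these data alone, is whether an amine or a carboxylic acid on this phenyl ring would give a lower number than compound 3. As far as these compounds go, the result of a 2,3-dimethoxyphenyl group at this place is also open.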